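A few compounds are considered here, and "the series" means these few. Any claim that something is new, unique, unknown or untested is made for them only; others in the source may bear on it.

Compound 1 `O=C(/C=C/c1cccc(OCc2ccccc2)c1)c1ccc(Br)cc1` gives 1000 nM in a functional assay on 2008 cells (Homo sapiens) for cytotoxicity, read by MTT assay, with a stated time of 68 h (on this read-out higher numbers stand for weaker inhibition and lower numbers for stronger inhibition), the lowest of the three numbers in hand. Compound 3 `O=C(/C=C/c1cccc(OCc2ccccc2)c1)c1ccccc1` gives 4900 nM, and compound 2 `COc1ccc(C(=O)/C=C/c2cccc(OCc3ccccc3)c2)cc1` gives 17200 nM. Compound 4 `Cc1ccc(C(=O)/C=C/c2cccc(OCc3ccccc3)c2)cc1` differs from compound 1 by methyl in place of bromo on an aromatic carbon. Among the compounds with values here, two measured steps bear on this change: a 4.9-fold higher number from compound 1 to compound 3 (0.69 log units; beyond the scatter), and a 17-fold higher number from compound 1 to compound 2 (1.24 log units; beyond the scatter). Both replacements of the bromo raised the number beyond the scatter, the methoxy more than the hydrogen; the step of a 3.5-fold lower number from compound 2 to compound 3 (0.55 log units; beyond the scatter) marks the span between the two. Within the data shown here, a methyl at this place has no direct precedent in the set, so a modest rise in this assay is expected, smaller than the methoxy step. The expected step is a 3.0-fold higher number from compound 1 to compound 4 (0.48 log units; beyond the scatter). Compound 4 is estimated at 3000 nM, within 1200 nM to 8000 nM.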

Compound 4, half-maximal inhibitory concentration: 12900 nM
Compound 4: middle estimate off by 4.3-fold (0.63 log units), on the low side; the whole stated range lies below it.
By their numbers in this assay, from the lowest: compound 1; then compound 3; then compounds 4 and 2 (each within the scatter of the next).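

Methyl turns out no better than methoxy at this place in this assay: the 4-bromophenyl to 4-methylphenyl change gives a large rise (a 13-fold higher number from compound 1 to compound 4 (1.11 log units; beyond the scatter)), and methyl and methoxy stay within the scatter of each other (a 1.3-fold lower number from compound 2 to compound 4 (0.12 log units; within the scatter)). Methyl also raises the number over hydrogen (a 2.6-fold higher number from compound 3 to compound 4 (0.42 log units; beyond the scatter)), so among the four groups shown only bromo gives a number lower than hydrogen does. No measurement in hand accounts for these steps.

As far as these compounds go, whether the low number of compound 1 is particular to bromo or extends to chloro or iodo remains open. From the compounds shown here alone, the response to an amine or a carboxylic acid at this place is also open.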